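A few compounds are considered here, and "the series" means these few. Any claim that something is new, unique, unknown or untested is made for them only; others in the source may bear on it.

Of the compounds shown here, three that share one core have been measured in an ADME assay on MT4 cells (Homo sapiens) for cytotoxicity, read by MTT assay; a lower number here means that less compound is tolerated, a higher number that more compound is tolerated. Compound 1 `O=C1c2ccccc2C(=O)N1CCOC(=S)N(C(=O)c1cc(F)ccc1F)c1ccc(Cl)cc1` gives 54000 nM, compound 2 `O=C1c2ccccc2C(=O)N1CCOC(=S)N(C(=O)c1ccc(F)c(F)c1)c1ccc(Cl)cc1` gives 52000 nM, and compound 3 `O=C1c2ccccc2C(=O)N1CCOC(=S)N(C(=O)c1ccc(Cl)c(Cl)c1)c1ccc(Cl)cc1` gives 35000 nM. Every gap among the three lies within the scatter, so compound 3 cannot be told apart from the other two.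

Compound 4 `Cc1cc(C(=O)N(C(=S)OCCN2C(=O)c3ccccc3C2=O)c2ccc(Cl)cc2)ccc1Br` has not been measured yet. It keeps the core of compound 3 and changes one group: 4-bromo-3-methylphenyl in place of 3,4-dichlorophenyl on a carbonyl carbon. In words, 4-bromo-3-methylphenyl comes in place of 3,4-dichlorophenyl on a carbonyl carbon.

The three measured steps all change a group at this same place: a 1.0-fold lower number from compound 1 to compound 2 (0.02 log units; within the scatter), a 1.5-fold lower number from compound 1 to compound 3 (0.19 log units; within the scatter) and a 1.5-fold lower number from compound 2 to compound 3 (0.17 log units; within the scatter). Each of them stays within the scatter. For the measured compounds named here, none of the measured compounds carries a bromine or a methyl group, so they offer only indirect guidance on this particular swap.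

Starting from compound 3 at 35000 nM, no step beyond the scatter is expected in this assay. The estimate amounts to an expected 1.1-fold higher number from compound 3 to compound 4 (0.04 log units; within the scatter). The value estimated for compound 4 is 38000 nM, with an expected range of 20000 nM to 70000 nM.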

Compound 4, half-maximal cytotoxic concentration: 18000 nM
The estimate for compound 4 lay 2.1-fold (0.32 log units) above the measured number, outside the stated range (below it).
By their numbers in this assay, from the lowest: compounds 4, 3, 2 and 1 (each within the scatter of the next, the first and the last beyond it).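

In this assay, this position on the carbonyl carbon now shows a change that stands clear of the scatter. For the compounds shown here, the 4-bromo-3-methylphenyl group gives a 2.9-fold lower number from compound 2 to compound 4 (0.46 log units; beyond the scatter) and a 3.0-fold lower number from compound 1 to compound 4 (0.48 log units; beyond the scatter), both modest, whereas every step among the earlier compounds stayed within the scatter, and the direct swap for 3,4-dichlorophenyl, a 1.9-fold lower number from compound 3 to compound 4 (0.29 log units; within the scatter), also stays within it, so the new group is set apart only from the two difluorophenyl compounds. The data shown offer no measurement that accounts for these steps.

It remains open whether the bromine, the methyl group or the two together carry the steps, as the compounds shown bring them in only as a pair. Going by these compounds alone, it also remains open how the number would respond to an amine or a carboxylic acid on this phenyl ring, since every group measured at this position so far carries only halogen atoms or a methyl group.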